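The source may hold more compounds than are shown below. What is called first, only, known or untested is meant among the compounds shown, and "the series" means these compounds.

Compound 2 `Cc1c(C(=O)Nc2ccc(Oc3ncnc4[nH]cc(-c5ccccc5)c34)c(F)c2)c(=O)c2cc(C(C)C)ccc2n1C` carries an isopropyl on the shared core and, in an assay on isolated protein for inhibition of tyrosine-protein kinase receptor UFO (Homo sapiens), read by FRET and Z'-LYTE, with a stated time of 1.5 h (on this read-out lower numbers stand for stronger inhibition and higher numbers for weaker inhibition), compound 2 gives 26 nM. Compound 1 `CCc1ccc2c(c1)c(=O)c(C(=O)Nc1ccc(Oc3ccnc(Cl)c3)c(F)c1)c(C)n2C` differs in more than one place and, in this assay, compound 1 reaches only the limit of the assay, > 10000 nM; that figure is a limit, not a number. Among the results so far, compound 2 therefore stands as the only one expressed as a number, the other being a limit. Compound 3 `COC(=O)c1ccc2c(c1)c(=O)c(C(=O)Nc1ccc(Oc3ncnc4[nH]cc(-c5ccccc5)c34)c(F)c1)c(C)n2C` is not yet measured. It differs from compound 2 in one place: methoxycarbonyl in place of isopropyl on an aromatic carbon. Within the data shown here, no measured pair shows what this change does, so the expected step of a 2.3-fold higher number from compound 2 to compound 3 (0.36 log units; beyond the scatter) is only an estimate, a modest weakening that may still sit within the usual scatter. Compound 3 is expected to give about 60 nM in this assay, with a likely range from 15 nM to 300 nM.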

Compound 3, half-maximal inhibitory concentration: > 10000 nM
Compound 3: only a limit was reported (the forecaster's own chance of this, stated with the estimate: 5%); middle value at least 160-fold (2.22 log units) from the limit.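

The change from isopropyl to methoxycarbonyl on this aromatic carbon is far from neutral in this assay: it gives an at least 380-fold higher number from compound 2 to compound 3 (2.58 log units; beyond the scatter). Among these compounds, compound 1 differs from compound 2 in more than one place, so this is the first pair to show that the group at this position alone can decide between a measurable value and none. This step is only a minimum, because compound 3 reached a limit of the assay rather than a number: the limit of > 10000 nM in this assay, at which 2 of the 3 values shown sit.

Among the compounds shown here, with only two groups compared at this position on otherwise identical compounds, the data cannot say which feature of methoxycarbonyl matters. A methyl group, an amine or a carboxylic acid at the same place would show whether the loss is specific to this ester or extends to other replacements for isopropyl.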